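A few compounds are considered here, and "the series" means these few. Any claim that something is new, unique, unknown or untested is made for them only; others in the source may bear on it.

- compound 1 `COc1cc(NC(C)CCCNC(=O)NNC(=O)Nc2ccc(Br)cc2)c2ncccc2c1` gives 101000 nM
- compound 2 `COc1cc(NC(C)CCCNC(=O)Nc2cc(C(F)(F)F)cc(C(F)(F)F)c2)c2ncccc2c1` gives 3100 nM
- compound 3 `COc1cc(NC(C)CCCNC(=O)NNC(=O)Nc2cccc(Cl)c2)c2ncccc2c1` gives 44000 nM

All three values come from a functional assay on HeLa cells (Homo sapiens) for inhibition, read by MTT assay, with a stated time of 72 h (on this read-out lower numbers stand for stronger inhibition and higher numbers for weaker inhibition), and compound 1 has the highest number of the three. Within the data shown here, compound 2 has the lowest, but it differs from compound 1 in more than one place, so it gives no clean step.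

The change under consideration leads to compound 4 `COc1cc(NC(C)CCCNC(=O)NNC(=O)Nc2ccc(O)cc2)c2ncccc2c1` and reads hydroxy in place of bromo on an aromatic carbon (hydroxy in place of bromo on an aromatic carbon, para to a large group). Among the measured compounds shown here, only one measured step bears on it, a 2.3-fold lower number from compound 1 to compound 3 (0.36 log units; beyond the scatter), where 3-chlorophenyl replaces 4-bromophenyl. For the measured compounds named here, no measured compound carries a hydroxy group, so the data do not settle the direction.

A small move in this assay is expected, no larger than that modest step, slightly downward and probably within the scatter. The estimate means an expected 1.4-fold lower number from compound 1 to compound 4 (0.16 log units; within the scatter) overall. Compound 4 is estimated at 70000 nM with an expected range of 25000 nM to 200000 nM overall.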

Compound 4, half-maximal inhibitory concentration: 85000 nM
For compound 4 the middle estimate is 1.2-fold (0.08 log units) below the measured one; measured number inside the range.
By their numbers in this assay, from the lowest: compound 2; then compounds 3, 4 and 1 (each within the scatter of the next, the first and the last beyond it).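

In this assay, hydroxy in place of bromo brings one hydrogen-bond donor and one hydrogen-bond acceptor to this aromatic carbon, yet the step is a 1.2-fold lower number from compound 1 to compound 4 (0.07 log units; within the scatter), so this change on the para position gives no measurable shift. The comparison with the other aryl group gives a 1.9-fold higher number from compound 3 to compound 4 (0.29 log units; within the scatter), so 4-hydroxyphenyl is not separated from 3-chlorophenyl either, although compound 1 and compound 3 do differ beyond the scatter. No measured evidence bears on why the number stays put at this position.

On these data alone, whether an amine or a carboxylic acid on the same aromatic carbon would move the number beyond the scatter remains open. Also open, as far as these compounds go, is how a hydroxy group would behave on the aryl end of compound 2 .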